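The source may report more compounds than this note shows. Statements on the series, on what has been measured and on what is new or still open speak of the compounds shown alone.

Compound 3 `C(#Cc1ccccn1)C1=CC(Sc2ccncc2)CCC1` gives 22 nM in an in vitro functional assay on Ltk cells for inhibition of metabotropic glutamate receptor 5 (Homo sapiens), read by calcium flux; on this read-out lower numbers stand for stronger inhibition and higher numbers for weaker inhibition. Compound 2 `O=C1c2ccccc2C(=O)N1C1C=C(C#Cc2ccccn2)CCC1` gives 27 nM in this assay, a number within the scatter of that of compound 3, so the two cannot be ranked against each other. Compound 1 `C(#Cc1ccccn1)C1=CC(Sc2ccc3ccccc3c2)CCC1` gives 213 nM in this assay, a number beyond the scatter above compound 3. Compound 3 thus holds the lowest of the three numbers, with compound 2 close and compound 1 well apart. Compound 4 `C(#Cc1ccccn1)C1=CC(Nc2cccnc2)CCC1` has not been measured. It differs from compound 3 in one place: (pyridin-3-yl)amino in place of (pyridin-4-yl)sulfanyl on a saturated ring carbon. Among the measured compounds shown here, no measured pair shows this change, so any step in this assay is uncertain, and a modest rise near the edge of the scatter is expected. Compound 4 is expected to give 60 nM, within a range from 15 nM to 250 nM. That expectation means a step of a 2.7-fold higher number from compound 3 to compound 4 (0.44 log units; beyond the scatter).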

Compound 4, half-maximal inhibitory concentration: 8.6 nM
The estimate for compound 4 lay 7.0-fold (0.84 log units) above the measured number; measured number below the stated range.
By their numbers in this assay, from the lowest: compound 4; then compounds 3 and 2 (each within the scatter of the next); then compound 1.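

In this assay, placing (pyridin-3-yl)amino instead of (pyridin-4-yl)sulfanyl on the saturated ring carbon brings a 2.6-fold lower number from compound 3 to compound 4 (0.41 log units; beyond the scatter) and so does not cost inhibition. This position therefore tolerates a group with a hydrogen-bond donor, which the leaving group lacks. Nothing available explains this step.

The step joins two changes, sulfanyl to amino and pyridin-4-yl to pyridin-3-yl, and the compounds shown cannot separate them. Neither (pyridin-4-yl)amino nor (pyridin-3-yl)sulfanyl is among them, and either would show how much each change contributes.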